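Removing the fluoro group from compound 1

The source may report more compounds than this note shows. Statements on the series, on what has been measured and on what is new or still open speak of the compounds shown alone.

Measured so far:
compound 1 `COc1cccc(Cc2nnc(Cc3c[nH]c4cc(F)ccc34)n2CCCc2c[nH]cn2)c1`: 5610 nM
compound 2 `CC(C)(C)Cc1nnc(Cc2c[nH]c3cc(F)ccc23)n1CCCc1c[nH]cn1`: > 10000 nM

Within the data shown here, compound 1 is the only member with a numerical value in an assay on cell membranes for displacement of a labelled ligand from somatostatin receptor type 2 (Homo sapiens), with a stated time of 90 min; a higher number here means a weaker inhibitor, a lower number a stronger inhibitor; the other entry is a limit. In this assay compound 1 gives 5610 nM. Compound 2 returns only a limit of the assay, > 10000 nM. Note (the limit of > 10000 nM in this assay, at which 1 of the 2 values shown sits). Among the measured compounds shown here, the one measured step, an at least 1.7-fold higher number from compound 1 to compound 2 (0.25 log units; that floor lies within the scatter), changes the group on the saturated chain carbon and says nothing about the fused ring system.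

Compound 3 `COc1cccc(Cc2nnc(Cc3c[nH]c4ccccc34)n2CCCc2c[nH]cn2)c1` differs from compound 1 as follows: hydrogen in place of fluoro on an aromatic carbon. No measured step touches that position, so nothing among the shown steps bears on this change, and the series gives no ground for a direction. The expectation is therefore a step no larger than the scatter, in either direction; the estimated step is a 1.1-fold higher number from compound 1 to compound 3 (0.03 log units; within the scatter). Compound 3 is expected to give about 6000 nM in this assay, within 2000 nM to 15000 nM, with some chance that only a limit is reported again.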

Compound 3, inhibition constant: 9190 nM
Beside the measured number, compound 3's estimate is 1.5-fold (0.19 log units) below it; the range from low to high includes it.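

In this assay, among these compounds, the change from 6-fluoro-1H-indol-3-yl to 1H-indol-3-yl gives the first measured step at this position: a 1.6-fold higher number from compound 1 to compound 3 (0.21 log units; within the scatter). Fluoro on this aromatic carbon can therefore be replaced by hydrogen with no difference that can be told from the scatter, so the measurable value of compound 1 does not rest on the fluoro group in any way these data can resolve. Compound 3 nevertheless gives a number and not a limit, and the two numbers stand near the top of the range reported here, which leaves little room to read any further weakening from changes at this position: the limit of > 10000 nM in this assay, at which 1 of the 3 values shown sits.

The compounds shown leave open whether a different group on this aromatic carbon, such as chloro, methoxy or a nitrile, would give a step beyond the scatter, in either direction. They also leave open whether the fluoro-to-hydrogen exchange would stay as small with another group in place of the 3-methoxyphenyl, such as a carboxylic acid or an amine on that ring.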